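The source may report more compounds than this note shows. Statements on the series, on what has been measured and on what is new or still open speak of the compounds shown alone.

Measured so far:
Compound 1, `COc1cc2c(Oc3ccc(NC(=O)c4nn(-c5ccccc5)c(=O)cc4C)cc3F)ccnc2cc1OCCCN1CCCCC1`: 280 nM
Compound 2, `COc1cc2c(Oc3ccc(NC(=O)c4nn(-c5ccccc5)c(=O)cc4C)cc3F)ccnc2cc1OCCCN1CCN(C)CC1`: 360 nM

Among the compounds with values here, in a functional assay on NCI-H460 cells (Homo sapiens) for inhibition, read by MTT assay, with a stated time of 72 h (a lower number here means a stronger inhibitor, a higher number a weaker inhibitor), the only measured step, a 1.3-fold higher number from compound 1 to compound 2 (0.11 log units; within the scatter), sits at the far end of the shared core, so compound 1 and compound 2 cannot be told apart. Compound 3, `COc1cc2c(Oc3ccc(NC(=O)c4nn(-c5ccc(Cl)cc5Cl)c(=O)cc4C)cc3F)ccnc2cc1OCCCN1CCCCC1`, instead changes the group on the aromatic nitrogen of the core: 2,4-dichlorophenyl in place of phenyl on an aromatic nitrogen. Within the data shown here, no measured step touches this position, so nothing here says how large the change will be or in which direction. Compound 3 is estimated at 150 nM, with a range from 40 nM to 700 nM. That estimate means an expected step of a 1.9-fold lower number from compound 1 to compound 3 (0.27 log units; within the scatter).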

Compound 3, half-maximal inhibitory concentration: 390 nM
Compound 3: the middle estimate sits 2.6-fold (0.41 log units) below what was measured; low and high end bracket the measured number.
By their numbers in this assay, from the lowest: compounds 1, 2 and 3 (each within the scatter of the next).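

In this assay, the group on the aromatic nitrogen now has its first measured step: 2,4-dichlorophenyl in place of phenyl gives a 1.4-fold higher number from compound 1 to compound 3 (0.14 log units; within the scatter). This swap brings two chlorine atoms onto the ring, yet compound 1 and compound 3 cannot be told apart. No supporting measurement bears on this result. As far as these compounds go, whether a single chlorine on the ring, a methoxy group on the ring, or a plain methyl group in place of the whole ring would read the same stays open.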